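A Longer Sulfur Chain and Cell Toxicity

The compounds below may be only part of what the source reports. "The series", "measured", "known", "first", "only" and "open" are said of these compounds alone.

Compound 1 `CSc1nc(O)c(C)c(C(C)c2c(F)cccc2F)n1` reports only a limit in a functional assay on MT4 cells (Homo sapiens) for cytotoxicity (on this read-out higher numbers stand for lower toxicity in this test and lower numbers for higher toxicity in this test), > 200000 nM. For the measured compounds named here, compound 2 `Cc1c(O)nc(SC(C)C)nc1C(C)c1c(F)cccc1F` gives 200000 nM, the only exact number so far in this assay. Compound 3 `CCC(C)Sc1nc(O)c(C)c(C(C)c2c(F)cccc2F)n1` differs from it by one change, (methyl in place of hydrogen on a saturated chain carbon, two bonds along the chain from a sulfur), which turns isopropyl into sec-butyl. Going by the values given here, the single measured step, a number no higher from compound 1 to compound 2 (the limit leaves the size open), put isopropyl in place of methyl on a sulfur, and its size stays open. It gives no sign of a large drop, so only a small shift is expected, a 1.3-fold lower number from compound 2 to compound 3 (0.10 log units; within the scatter), with no clear move beyond the scatter. For compound 3 the estimated value is 160000 nM, with an expected range of 70000 nM to 230000 nM.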

Compound 3, half-maximal cytotoxic concentration: > 200000 nM
Compound 3 was reported as a limit (the forecaster's own chance of this, stated with the estimate: 45%); at least 1.2-fold (0.09 log units) between middle value and limit.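

In this assay, the methyl that turns isopropyl into sec-butyl gives a number no lower from compound 2 to compound 3 (the limit leaves the size open), so this added carbon on the chain brings no sign of higher toxicity. The step between compound 1 and compound 3 cannot be read. The values shown stop at one limit: the limit of > 200000 nM in this assay, at which 2 of the 3 values shown sit.

Still open, going by these compounds, is whether a longer chain, such as n-hexyl, or an amine on the sulfur would bring a clearly lower number in this assay.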